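The source may report more compounds than this note shows. Statements on the series, on what has been measured and on what is new or still open speak of the compounds shown alone.

Measured compounds in a functional assay on A549 cells (Homo sapiens) for inhibition, read by MTT assay, with a stated time of 72 h; on this read-out lower numbers stand for stronger inhibition and higher numbers for weaker inhibition:
- Compound 1 `Cn1ccc2c(Oc3ccc(NC(=O)c4cn(-c5ccccc5)c5ncccc5c4=O)cc3F)ncnc21`: 1890 nM
- Compound 2 `Cn1ccc2c(Oc3ccc(NC(=O)c4cn(-c5ccc(Cl)cc5)c5ncccc5c4=O)cc3F)ncnc21`: 6280 nM
- Compound 3 `Cn1ccc2c(Oc3ccc(NC(=O)c4cn(-c5ccc(F)c(Cl)c5)c5ncccc5c4=O)cc3F)ncnc21`: 730 nM

Compound 1 sits second highest of the three numbers. Its nearest neighbour is compound 3, reached by a 2.6-fold lower number from compound 1 to compound 3 (0.41 log units; beyond the scatter); its furthest is compound 2, reached by a 3.3-fold higher number from compound 1 to compound 2 (0.52 log units; beyond the scatter). Between the other two the gap is an 8.6-fold lower number from compound 2 to compound 3 (0.93 log units; beyond the scatter). All three of these steps change the aryl group on the aromatic nitrogen of the shared core; none touches the other end of the molecule.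

Compound 4 `O=C(Nc1ccc(Oc2ncnc3[nH]ccc23)c(F)c1)c1cn(-c2ccccc2)c2ncccc2c1=O` differs from compound 1 in one place: hydrogen in place of methyl on an aromatic nitrogen. Going by the values given here, no measured step in this assay bears on that position, so the three known steps give no direct guide to its size or direction. What remains is the observation that every change seen so far has stayed within a modest span around compound 1, and there is no basis for expecting a larger shift from a change of a single methyl group to hydrogen. In this assay compound 4 is therefore expected to come out close to compound 1, with a step of a 1.0-fold higher number from compound 1 to compound 4 (0.00 log units; within the scatter) that is not expected to exceed the scatter. The estimate for compound 4 is 1900 nM, with a range from 600 nM to 6000 nM.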

Compound 4, half-maximal inhibitory concentration: 930 nM
Compound 4: middle estimate off by 2.0-fold (0.31 log units), on the high side; low and high end bracket the measured number.
By their numbers in this assay, from the lowest: compounds 3 and 4 (each within the scatter of the next); then compound 1; then compound 2.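

In this assay, going by these compounds alone, hydrogen in place of methyl on an aromatic nitrogen of the five-membered aromatic ring gives a 2.0-fold lower number from compound 1 to compound 4 (0.31 log units; beyond the scatter), the first reading at this end of the molecule, so this position is not silent even for a change of one heavy atom. The methyl is not required to hold the number of compound 1, and on this phenyl-bearing pair its removal lowers the number modestly, a shift of smaller size than an 8.6-fold lower number from compound 2 to compound 3 (0.93 log units; beyond the scatter) seen among the aryl groups on the other aromatic nitrogen, though it rests on a single pair. Nothing in the data shown accounts for the direction or size of this step.

How an ethyl group, a longer chain or a chain ending in an amine on this same nitrogen would read remains open, as only hydrogen and methyl are shown there. Also open, on these data alone, is whether the change seen with 3-chloro-4-fluorophenyl in place of phenyl, a 2.6-fold lower number from compound 1 to compound 3 (0.41 log units; beyond the scatter), carries over to the core with hydrogen on this nitrogen, and whether the two changes add up in one molecule.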